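Butoxy to pyrrolidin-1-yl on the carbonyl carbon

The source may report more compounds than this note shows. Statements on the series, on what has been measured and on what is new or still open speak of the compounds shown alone.

In a functional assay on Jurkat cells (Homo sapiens) for antiproliferative activity, read by MTT assay, with a stated time of 48 h (a higher number here means a weaker inhibitor, a lower number a stronger inhibitor), compound 1 (`COC(=O)/C=C/c1ccc2c(c1)N(Cc1ccc(OC)cc1)C(=O)C2=O`) gives 3110 nM and compound 2 (`CCCCOC(=O)/C=C/c1ccc2c(c1)C(=O)C(=O)N2Cc1ccc(OC)cc1`) gives 220 nM as its value. Compound 3 (`CCCCOC(=O)/C=C/c1ccc2c(c1)C(=O)C(=O)N2Cc1ccc(Br)cc1`) at 700 nM lies between the two. Compound 4 (`O=C1C(=O)N(Cc2ccc(Br)cc2)c2ccc(/C=C/C(=O)N3CCCC3)cc21`) has pyrrolidin-1-yl in place of butoxy on a carbonyl carbon. Among the compounds with values here, the one measured single-place step (a 3.2-fold higher number from compound 2 to compound 3 (0.50 log units; beyond the scatter)) is modest but sits on an aromatic carbon, so it does not test this change. Within the data shown here, no measured compound carries pyrrolidin-1-yl. A modest rise in the number in this assay is therefore only a cautious expectation. The expected step is an estimated one (a 2.1-fold higher number from compound 3 to compound 4 (0.33 log units; beyond the scatter)). For compound 4 the expected value is 1500 nM within an estimated range (500 nM to 4500 nM).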

Compound 4, half-maximal inhibitory concentration: 3190 nM
Beside the measured number, compound 4's estimate is 2.1-fold (0.33 log units) below it; low and high end bracket the measured number.
By their numbers in this assay, from the lowest: compound 2; then compound 3; then compounds 1 and 4 (each within the scatter of the next).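

In this assay, the carbonyl carbon now has a measured single-place change: pyrrolidin-1-yl in place of butoxy gives a 4.6-fold higher number from compound 3 to compound 4 (0.66 log units; beyond the scatter). The number therefore responds to the group on this carbonyl carbon, even though the heavy-atom count stays the same. No evidence here accounts for the rise.

The step swaps oxygen for nitrogen and brings in a ring together, so the two remain unseparated. An open-chain amide such as diethylamide, or a free carboxylic acid, at this carbonyl carbon would leave different parts of that change in place.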